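The compounds below may be only part of what the source reports. "The series", "measured", "known", "first", "only" and "open" are said of these compounds alone.

Compound 1 `COc1ccc2c(c1)c(/C=N\NC(=O)c1cn(C)c3ccccc13)cn2Cc1ccc(Cl)cc1`: in a functional assay on MDA-MB-231 cells (Homo sapiens) for cytotoxicity (on this read-out lower numbers stand for stronger inhibition and higher numbers for weaker inhibition), compound 1 gives > 100000 nM, which is a limit of the assay and not a number.
Compound 2 `COc1ccc2c(c1)c(/C=N\NC(=O)c1c[nH]c3ccccc13)cn2Cc1ccc(Cl)cc1`: in this assay compound 2 gives 82700 nM.
Compound 3 `COc1ccc(Cn2cc(/C=N\NC(=O)c3c[nH]c4ccccc34)c3ccc(F)cc32)cc1`: in this assay compound 3 gives 71200 nM.
Compound 4 `COc1ccc(Cn2cc(/C=N\NC(=O)c3cn(C)c4ccccc34)c3ccc(F)cc32)cc1`: not yet measured.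

The three measured compounds all sit at the weak end of the range. Compounds 2 and 3 give numbers that lie within the usual scatter of each other, so no order between them can be stated. The difference between the cores of compound 2 and compound 3 is not broken down here.

From compound 2 to compound 1 one change is made: methyl in place of hydrogen on an aromatic nitrogen. This step reads an at least 1.2-fold higher number from compound 2 to compound 1 (0.08 log units; that floor lies within the scatter). Only a floor can be given for it, because the limit of > 100000 nM in this assay, at which 1 of the 3 values shown sits, is where compound 1 sits.

The same change is made from compound 3 to compound 4: methyl in place of hydrogen on an aromatic nitrogen. The place line is identical word for word in both cases, so this is the same change, made a second time on a different core. Going by the values given here, the one earlier instance of this change carried a weak value upward, as an at least 1.2-fold higher number from compound 2 to compound 1 (0.08 log units; that floor lies within the scatter) shows. The same direction is expected for compound 4. The starting point is compound 3 with 71200 nM.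

The expected step is estimated as a 2.0-fold higher number from compound 3 to compound 4 (0.29 log units; within the scatter). For compound 4 the estimate is 140000 nM, with a likely range from 60000 nM to 350000 nM, and it is expected that the assay may again return only a limit.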

Compound 4, half-maximal inhibitory concentration: 17700 nM
The estimate for compound 4 lay 7.9-fold (0.90 log units) above the measured number, and the stated range ends above it.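

In this assay, methyl in place of hydrogen on an aromatic nitrogen, the change from 1H-indol-3-yl to 1-methyl-1H-indol-3-yl, gives a 4.0-fold lower number from compound 3 to compound 4 (0.60 log units; beyond the scatter), a modest step towards stronger inhibition. Set beside the earlier instance of the same change, this step differs, so in this series the result on one core did not carry over to the other: the same change on two cores in this assay, an at least 1.2-fold higher number (0.08 log units; that floor lies within the scatter) from compound 2 to compound 1 and a 4.0-fold lower number (0.60 log units; beyond the scatter) from compound 3 to compound 4, at least 4.8-fold (0.68 log units) apart, beyond the scatter of two such steps This rests on two pairs only, so it gives no rule for any further core and does not show which feature of the cores lies behind the gap, and the earlier step is only a floor, as compound 1 stands at a limit of the assay: the limit of > 100000 nM in this assay, at which 1 of the 4 values shown sits.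

On these data alone, it remains open whether an ethyl group, a longer chain or an acetyl group on the same aromatic nitrogen would follow the methyl step on the core of compound 3. Also open is which of the parts that differ between the core of compound 2 and the core of compound 3 sets the two steps apart, as no compound shown changes those parts one at a time.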